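This account rests on a few compounds, and the source may have more. Where it says the series, first, only, none or still open, it means among the compounds named here.

Measured so far in this assay:
compound 1 `COc1cc(NC(=O)c2ccc(Cl)cc2)ccc1NS(C)(=O)=O`: > 250000 nM
compound 2 `COc1cc(NC(=O)c2ccc(Cl)c([N+](=O)[O-])c2)ccc1NS(C)(=O)=O`: 164000 nM
compound 3 `CCS(=O)(=O)Nc1ccc(NC(=O)c2ccc(Cl)cc2)cc1Cl`: > 250000 nM

The read-out is an ADME assay on HEK293 cells (Homo sapiens) for cytotoxicity, read by MTT assay, with a stated time of 48 h; a higher number here means a weaker inhibitor, a lower number a stronger inhibitor. For compound 1 the value > 250000 nM is a limit of the assay, not a number. Compound 2 gives 164000 nM in this assay. The step of an at least 1.5-fold lower number from compound 1 to compound 2 (0.18 log units; that floor lies within the scatter) comes from nitro in place of hydrogen on an aromatic carbon; only a floor can be given because compound 1 sits at the limit of > 250000 nM in this assay, at which 2 of the 3 values shown sit. For compound 3 the value > 250000 nM is likewise a limit. How the core of compound 3 differs from the core of compound 1 is not broken down here.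

Compound 4 `CCS(=O)(=O)Nc1ccc(NC(=O)c2ccc(Cl)c([N+](=O)[O-])c2)cc1Cl` is not yet measured. It carries nitro in place of hydrogen on an aromatic carbon, the same change as from compound 1 to compound 2. The expected step is an at least 1.5-fold lower number from compound 3 to compound 4 (0.19 log units; that floor lies within the scatter), set at the same size because an at least 1.5-fold lower number from compound 1 to compound 2 (0.18 log units; that floor lies within the scatter) is the only comparable step shown. Compound 4 is therefore estimated at 160000 nM, expected between 80000 nM and 300000 nM.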

Compound 4, half-maximal inhibitory concentration: 63800 nM
For compound 4 the middle estimate is 2.5-fold (0.40 log units) above the measured one; measured number outside the range, below it.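

In this assay, nitro in place of hydrogen on an aromatic carbon gives an at least 3.9-fold lower number from compound 3 to compound 4 (0.59 log units; beyond the scatter) on the second core. The same change thus goes with a lower number on both cores shown, but whether its size differs between them stays unsettled: the same change on two cores in this assay, an at least 1.5-fold lower number (0.18 log units; that floor lies within the scatter) from compound 1 to compound 2 and an at least 3.9-fold lower number (0.59 log units; beyond the scatter) from compound 3 to compound 4; the limit leaves it open whether they differ. Neither step has a true size, and two cores do not make a rule for the series: the limit of > 250000 nM in this assay, at which 2 of the 4 values shown sit.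

Only nitro is shown at this place, so it remains open whether another group, such as an amine or a carboxylic acid, would go with a similar step. Also open, from the compounds shown here alone, is the true size of the step on a core whose parent compound gives a number rather than a limit.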